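Working notes: sulfonyl substitution, compounds 1 to 4

This account rests on a few compounds, and the source may have more. Where it says the series, first, only, none or still open, it means among the compounds named here.

Measured compounds, with their values in a functional assay on the whole organism (aorta) with Rattus norvegicus as the target; a lower number here means a smaller maximal response, a higher number a larger maximal response:
Compound 1 `CNS(=O)(=O)c1ccc2c(c1)C(n1ccccc1=O)=CC(C)(C)O2`: 85.8%
Compound 2 `CC1(C)C=C(n2ccccc2=O)c2cc(S(=O)(=O)Nc3ccc([N+](=O)[O-])cc3)ccc2O1`: 82.2%
Compound 3 `CC1(C)C=C(n2ccccc2=O)c2cc(S(=O)(=O)NC(=O)Nc3ccccc3)ccc2O1`: 90.8%

Compound 3 stands highest of the three numbers, but its steps to the others stay within the scatter: a number 5 percentage points higher from compound 1 to compound 3 (within the scatter) and a number 8.6 percentage points higher from compound 2 to compound 3 (within the scatter). The third measured step, a number 3.6 percentage points lower from compound 1 to compound 2 (within the scatter), is also within the scatter, so every change made so far on the sulfonamide nitrogen has left the maximal response unmoved.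

Compound 4 `CC1(C)C=C(n2ccccc2=O)c2cc(S(=O)(=O)c3ccccc3)ccc2O1` differs from compound 3 by phenyl in place of (phenylcarbamoyl)amino on a sulfonyl sulfur. Among the compounds with values here, no measured step touches the sulfonyl sulfur itself, so the three steps on the sulfonamide nitrogen are the only guide, and all were flat. On that basis the expected step is a number 4.8 percentage points lower from compound 3 to compound 4 (within the scatter), with no change beyond the scatter. For compound 4 in this assay the estimate is 86%, with a range from 70% to 100%.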

Compound 4, largest response reached (Emax), in percent of the reference or control that the assay uses: 79.3%
The estimate for compound 4 lay 6.7 percentage points above the measured number; the measured number falls inside the stated range.
By their numbers in this assay, from the lowest: compounds 4, 2, 1 and 3 (each within the scatter of the next, the first and the last beyond it).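

Within the data shown here, at the sulfonyl sulfur, this assay gives the first step beyond the scatter (a number 11.5 percentage points lower from compound 3 to compound 4 (beyond the scatter)), so the maximal response is not insensitive to every change here. The separation is confined to this one pair: phenyl stays within the scatter of the other two sulfonyl substituents (a number 2.9 percentage points lower from compound 2 to compound 4 (within the scatter); a number 6.5 percentage points lower from compound 1 to compound 4 (within the scatter)). Nothing available explains the step. Going by these compounds, whether the modest step from compound 3 to compound 4 belongs to the loss of (phenylcarbamoyl)amino or to the entry of phenyl stays open. A plain amino group or a methyl on the sulfonyl sulfur would help to separate the two.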